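From compound 3 to compound 4: hydrogen for fluoro

A few compounds are considered here, and "the series" means these few. Any claim that something is new, unique, unknown or untested is made for them only; others in the source may bear on it.

In a functional assay on SW480 cells (Homo sapiens) for antiproliferative activity, with a stated time of 72 h (on this read-out lower numbers stand for stronger inhibition and higher numbers for weaker inhibition), compound 1 (`O=C(COc1ccc(CNC2CC=C(c3c[nH]c4cccc(F)c34)CC2)c(F)c1)NO`) gives 189 nM and compound 2 (`O=C(COc1ccc(CNC2CC=C(c3c[nH]c4ccccc34)CC2)c(F)c1)NO`) gives 1150 nM. In this assay compound 3 (`Cc1[nH]c2cccc(F)c2c1C1=CCC(NCc2ccc(OCC(=O)NO)cc2F)CC1`) has no number, its entry reading "nd" (no result reported), so it offers no starting value. Compound 4 (`Cc1[nH]c2ccccc2c1C1=CCC(NCc2ccc(OCC(=O)NO)cc2F)CC1`) comes from compound 3 by one change, hydrogen in place of fluoro on an aromatic carbon.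

Among the compounds with values here, the one measured step that bears on this is the same exchange, a 6.1-fold higher number from compound 1 to compound 2 (0.78 log units; beyond the scatter), a modest step beyond the scatter. A single pair is thin support, and nothing yet shows that it carries over to compound 4. A step of similar modest size towards a higher number in this assay is expected, though it cannot be measured from compound 3 without a value there. The estimate therefore leans on compound 2 at 1150 nM, with a wide range. For compound 4 the estimated value is 1000 nM, with an expected range of 250 nM to 4000 nM.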

Compound 4, half-maximal inhibitory concentration: 170 nM
Estimate against measurement, compound 4: 5.9-fold (0.77 log units) above; measured number below the stated range.
By their numbers in this assay, from the lowest: compounds 4 and 1 (each within the scatter of the next); then compound 2.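

In this assay methyl in place of hydrogen on an aromatic carbon gives a 6.8-fold lower number from compound 2 to compound 4 (0.83 log units; beyond the scatter) and so, with no fluoro on the six-membered aromatic ring, the number returns to the level of compound 1. That level is borne out by a 1.1-fold lower number from compound 1 to compound 4 (0.05 log units; within the scatter) for 2-methyl-1H-indol-3-yl in place of 4-fluoro-1H-indol-3-yl, so among these compounds the fluoro of compound 1 is not the only route to such a number. No measurement shown here explains either step.

As far as these compounds go, the step from compound 3 to compound 4 cannot be read, as compound 3 has no number, so it stays open whether fluoro still matters once the methyl is present. Also open, from the compounds shown here alone, is whether chloro or methoxy in place of the fluoro, or ethyl in place of the methyl, would hold the number.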